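From phenyl to phenoxy at the limit of the assay

This account rests on a few compounds, and the source may have more. Where it says the series, first, only, none or still open, it means among the compounds named here.

Compound 1 `CCOC(=O)c1c(-c2cccc(Oc3ccccc3)c2)[nH]c2cc(OC)ccc2c1=O` gives > 21500 nM as a limit
Compound 2 `CCOC(=O)c1c(-c2cccc(Oc3ccccc3)c2)[nH]c2cc(OC)c(OC)cc2c1=O` gives > 21500 nM as a limit
Compound 3 `CCOC(=O)c1c(-c2cccc(-c3ccccc3)c2)[nH]c2cc(OC)c(Cl)cc2c1=O` gives > 21500 nM as a limit

All three entries come from an ADME assay on BJ cells (Homo sapiens) for cytotoxicity, read by luminescence, with a stated time of 72 h (on this read-out higher numbers stand for an effect only at larger amounts of compound and lower numbers for an effect already at smaller amounts), and each is a limit of the assay, not a number. Compound 3 stands at > 21500 nM and that is a limit. Every measured compound sits at the limit of > 21500 nM in this assay, at which 3 of the 3 values shown sit, in the data so far, so compound 3 has no readable rank among them.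

Compound 4 `CCOC(=O)c1c(-c2cccc(Oc3ccccc3)c2)[nH]c2cc(OC)c(Cl)cc2c1=O` differs from compound 3 in one place: phenoxy in place of phenyl on an aromatic carbon with phenoxy in place of phenyl on an aromatic carbon. Among the measured compounds shown here, the one measured step is a step that the two limits leave unreadable from compound 1 to compound 2 and it concerns methoxy in place of hydrogen on an aromatic carbon, a different change that gives no size to carry over. Compound 2 already carries the phenoxy group and gives > 21500 nM as a limit. On that basis no step beyond the scatter is expected in this assay and no direction can be told. The expected size is a number no higher from compound 3 to compound 4 (the limit leaves the size open) and the most likely report is again only a limit. For compound 4 the estimate is 21500 nM with an expected range from 12000 nM to 40000 nM as estimated here.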

Compound 4, half-maximal effective concentration: > 21500 nM
Compound 4 ended at the assay's limit; the forecaster's own chance of this, stated with the estimate: 85%; the middle value sits exactly at the limit.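

No step can be read from compound 3 to compound 4, or from compound 1 or compound 2 to compound 4, because both ends of each pair are limits, not numbers: the limit of > 21500 nM in this assay, at which 4 of the 4 values shown sit.

The compounds shown leave open what amount of each gives an effect in this assay, and whether swapping phenyl for phenoxy changes that amount at all.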